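A few compounds are considered here, and "the series" means these few. Any claim that something is new, unique, unknown or untested is made for them only; others in the source may bear on it.

Compound 1 `C=C1[C@H](OCC(C)C)[C@@H](OC(C)=O)[C@@H](OC(C)=O)C(C)(C)/C=C/[C@H](C)[C@H](OC(=O)c2ccccc2)[C@@]2(O)C[C@@](C)(OC(C)=O)[C@H](OC(C)=O)[C@@H]2[C@H]1OCC(C)C`: > 100000 nM
Compound 2 `C=C1[C@H](OC(C)=O)[C@@H](OC(=O)c2cccc(C)c2)[C@@H](OC(C)=O)C(C)(C)/C=C/[C@H](C)[C@H](OC(=O)c2ccccc2)[C@@]2(O)C[C@@](C)(OC(C)=O)[C@H](OC(C)=O)[C@@H]2[C@H]1OCC(C)C`: > 100000 nM
Compound 3 `C=C1[C@H](OC(C)=O)[C@@H](OC(C)=O)[C@@H](OC(C)=O)C(C)(C)/C=C/[C@H](C)[C@H](OC(=O)c2ccccc2)[C@@]2(O)C[C@@](C)(OC(C)=O)[C@H](OC(C)=O)[C@@H]2[C@H]1OCC(C)C`: > 100000 nM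

In a functional assay on NCI/ADR-RES cells (Homo sapiens) for antiproliferative activity, read by MTT assay, with a stated time of 48 h (a higher number here means a weaker inhibitor, a lower number a stronger inhibitor), compound 3 gives > 100000 nM, which is a limit of the assay and not a number. Compound 1 likewise reaches only a limit, > 100000 nM. Compound 2 also sits at a limit, > 100000 nM. All three values therefore rest at the limit of > 100000 nM in this assay, at which 3 of the 3 values shown sit, and the two steps onto compound 3, a step that the two limits leave unreadable from compound 1 to compound 3 and a step that the two limits leave unreadable from compound 2 to compound 3, cannot be given a size in either direction.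

Compound 4 `C=C1[C@H](OC(C)=O)[C@@H](OC(C)=O)[C@@H](OC(C)=O)C(C)(C)/C=C/[C@H](C)[C@H](OC(=O)c2ccccc2)[C@@]2(O)C[C@@](C)(OC(=O)c3cccc(C)c3)[C@H](OC(C)=O)[C@@H]2[C@H]1OCC(C)C` differs from compound 3 by 3-methylphenyl in place of methyl on a carbonyl carbon. The measured step closest to it in kind is a step that the two limits leave unreadable from compound 2 to compound 3, the same exchange of methyl and 3-methylphenyl on a carbonyl carbon at another ester of the shared core, but since both ends of that step are limits it yields nothing readable. Going by the values given here, no step gives a size, so the change from compound 3 to compound 4 has no measured precedent that can be scaled.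

Compound 4 is expected to give 150000 nM, within an estimated range of 50000 nM to 500000 nM. The expected step that the limit leaves unreadable from compound 3 to compound 4 is thus none beyond the scatter, and a limit rather than a number is the likely report for compound 4 in this assay.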

Compound 4, half-maximal inhibitory concentration: > 100000 nM
Compound 4 gave a limit, no number; the forecaster's own chance of this, stated with the estimate: 85%; the middle value lies beyond the limit too.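

In this assay compound 4 gives > 100000 nM, a limit and not a number, so no size can be read for its step from compound 3. The compounds shown leave open which change on the shared core, if any, would give a readable value: the limit of > 100000 nM in this assay, at which 4 of the 4 values shown sit.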